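Fluoro for Hydrogen on Two Cores, Kinase Inhibition

The source may hold more compounds than are shown below. What is called first, only, known or untested is meant among the compounds shown, and "the series" means these compounds.

Measured so far:
compound 1, `Cn1cnc2c(SCc3ccccc3)ncnc21`, gives 1%
compound 2, `Cn1cnc2c(SCc3ccc(F)cc3)ncnc21`, gives 6%
compound 3, `c1ccc(-[n+]2c[nH]c3ncncc32)cc1`, gives 0%

All three values come from an assay on isolated protein for inhibition of Rho-associated protein kinase 1 (Homo sapiens), tested at 30 uM; a higher number here means more inhibition at the concentration tested (going by the name of the read-out), a lower number less inhibition. None of the three measured compounds shows appreciable inhibition at the concentration tested, and the three numbers lie within the scatter of one another.

Compound 1 and compound 2 differ by fluoro in place of hydrogen on an aromatic carbon. The step that this change made is a number 5 percentage points higher from compound 1 to compound 2 (within the scatter).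

Compound 3 stands on a different core from compound 1; the difference between the two cores is not broken down here.

Compound 4, `Fc1ccc(-[n+]2c[nH]c3ncncc32)cc1`, not yet measured, arises from compound 3 by fluoro in place of hydrogen on an aromatic carbon. Among the compounds with values here, this is the same kind of change as the one from compound 1 to compound 2, though the surroundings differ: in compound 4 the fluoro sits para to a group of 9 heavy atoms, whereas in compound 2 it sits para to a large group.

The step from compound 3 to compound 4 in this assay is expected to be a number 3 percentage points higher from compound 3 to compound 4 (within the scatter), because the corresponding step of a number 5 percentage points higher from compound 1 to compound 2 (within the scatter) stayed within the scatter and compound 3 starts from 0%. Compound 4 is thus estimated at 3%, with a likely range from -5% to 12%.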

Compound 4, a percentage reported as inhibition, at one concentration (the size of the read-out at that concentration, not a potency): 2%
Beside the measured number, compound 4's estimate is 1 percentage points above it; low and high end bracket the measured number.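

In this assay fluoro in place of hydrogen on an aromatic carbon gives a number 2 percentage points higher from compound 3 to compound 4 (within the scatter) on the core of compound 3, so this step, like the earlier one, is no measurable change. Set side by side, the two steps show no difference in how the change reads out on the two cores: the same change on two cores in this assay, a number 5 percentage points higher (within the scatter) from compound 1 to compound 2 and a number 2 percentage points higher (within the scatter) from compound 3 to compound 4, 3 percentage points apart, within the scatter of two such steps. This agreement is only one of two null results, since none of the four compounds shows appreciable inhibition at the concentration tested, and it does not show that a real gain from fluoro would carry from one core to the other.

The compounds shown leave open whether any other group at this place on the aromatic ring, such as an amine, a carboxylic acid or a longer chain, moves the read-out on either core. Also open, from the compounds shown here alone, is how fluoro behaves on a core that already gives clear inhibition.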